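Diisopropylamino in Place of Piperidin-1-yl: An Expectation

A few compounds are considered here, and "the series" means these few. Any claim that something is new, unique, unknown or untested is made for them only; others in the source may bear on it.

Measured so far:
compound 1 `Cc1ccc2c(=O)c(CSC(=S)N3CCCCC3)coc2c1` gives 800 nM in a functional assay on MCF7 cells (Homo sapiens) for antiproliferative activity, read by MTT assay, with a stated time of 72 h; a lower number here means a stronger inhibitor, a higher number a weaker inhibitor
compound 2 `O=c1c(CSC(=S)N2CCCCC2)coc2cc(Cl)ccc12` gives 380 nM in this assay

Compound 1 holds the highest number of the two, and the step of a 2.1-fold lower number from compound 1 to compound 2 (0.32 log units; beyond the scatter) separates it from compound 2. Compound 3 `Cc1ccc2c(=O)c(CSC(=S)N(C(C)C)C(C)C)coc2c1` differs from compound 1 in one place: diisopropylamino in place of piperidin-1-yl on a thiocarbonyl carbon is the change. For the measured compounds named here, the only measured step alters a group on an aromatic carbon and leaves the amine on the thiocarbonyl carbon untouched, so no measured step bears on this change. With nothing pointing either way, the expected step is no change at the digits printed from compound 1 to compound 3 (within the scatter) in this assay and stays within the scatter. Compound 3 is estimated at 800 nM with a range from 300 nM to 2500 nM in this assay.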

Compound 3, half-maximal inhibitory concentration: 6600 nM
For compound 3 the middle estimate is 8.3-fold (0.92 log units) below the measured one; measured number outside the range, above it.
By their numbers in this assay, from the lowest: compound 2; then compound 1; then compound 3.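

The amine on the thiocarbonyl carbon matters in this assay: diisopropylamino in place of piperidin-1-yl gives an 8.3-fold higher number from compound 1 to compound 3 (0.92 log units; beyond the scatter). The group that leaves has a ring and the one that enters has none, but a single step cannot show whether that difference is what counts. No evidence here explains the step.

From the compounds shown here alone, it remains open how other amines at this place, such as pyrrolidin-1-yl, morpholin-4-yl or dimethylamino, would compare. Going by these compounds, it is also open whether the same change would have a similar effect with chloro in place of methyl.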